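Swapping a Thiazole Amide Cap for a Pyridine

The source may hold more compounds than are shown below. What is called first, only, known or untested is meant among the compounds shown, and "the series" means these compounds.

Compound 1 `Nc1ncnc2c1ncn2[C@@H]1O[C@H](CNCc2ccc(-c3cc(C(F)(F)F)ccc3Cl)o2)[C@@H](O)[C@H]1O` gives 32400 nM in an assay for inhibition of histone-lysine N-methyltransferase, H3 lysine-79 specific (Homo sapiens), read by scintillation counting, with a stated time of 1 h, in the presence of a further agent that is not named here; on this read-out lower numbers stand for stronger inhibition and higher numbers for weaker inhibition.
Compound 2 `O=C(Nc1ccn(CCCN2CCC(c3ccccc3)CC2)c(=O)n1)OCc1ccccc1` gives 710000 nM in this assay.
Compound 3 `Nc1ncnc2c1ncn2[C@@H]1O[C@H](CNCc2ccc(OCC(=O)Nc3nccs3)cc2)[C@@H](O)[C@H]1O` gives 90400 nM in this assay.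

Among these three numbers compound 3 holds the second highest. Compound 1 lies nearest to it, with a lower number, a gap beyond the usual scatter; compound 2 lies furthest, with a higher number, again beyond the scatter. Compound 4 `Nc1ncnc2c1ncn2[C@@H]1O[C@H](CNCc2ccc(OCC(=O)Nc3ccccn3)cc2)[C@@H](O)[C@H]1O` differs from compound 3 in one place: pyridin-2-yl in place of 1,3-thiazol-2-yl on an amide-type nitrogen. For the measured compounds named here, no measured pair shows this exchange, so its size is unknown. Replacing one ring by the other on the amide-type nitrogen is expected to move the number little, if at all beyond the scatter. Compound 4 is therefore expected to give about 100000 nM in this assay, between 35000 nM and 300000 nM. The step this estimate means, a 1.1-fold higher number from compound 3 to compound 4 (0.04 log units; within the scatter), is expected to stay near the scatter.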

Compound 4, half-maximal inhibitory concentration: 54900 nM
For compound 4 the middle estimate is 1.8-fold (0.26 log units) above the measured one; measured number inside the range.
By their numbers in this assay, from the lowest: compounds 1, 4 and 3 (each within the scatter of the next, the first and the last beyond it); then compound 2.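

On the amide-type nitrogen, pyridin-2-yl stands in place of 1,3-thiazol-2-yl with a 1.6-fold lower number from compound 3 to compound 4 (0.22 log units; within the scatter) in this assay so the two groups cannot be told apart here. For the compounds shown here, this is the first exchange at this position with a measured size, and it shows that a five-membered aromatic ring holding sulfur and a six-membered aromatic ring without sulfur read alike. Nothing available explains this result.

Still open, from the compounds shown here alone, is how a non-aromatic group on that nitrogen, such as cyclohexyl or methyl, would read. Also open, going by these compounds, is whether an amine or a carboxylic acid on the pyridin-2-yl ring would move the number beyond the scatter.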